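The source may hold more compounds than are shown below. What is called first, only, known or untested is meant among the compounds shown, and "the series" means these compounds.

Measured in a functional assay on A-375 cells (Homo sapiens) for inhibition, read by MTT assay, with a stated time of 120 h; on this read-out higher numbers stand for weaker inhibition and lower numbers for stronger inhibition:

- Compound 1 `O=C(/C=C/c1ccc(NC(=O)Nc2ccc(Cl)c(C(F)(F)F)c2)cc1)NC1CCC1`: 15400 nM
- Compound 2 `CNC(=O)/C=C/c1ccc(NC(=O)Nc2ccc(Cl)c(C(F)(F)F)c2)cc1`: 20900 nM
- Compound 3 `CNC(=O)c1cccc(-c2ccc(NC(=O)Nc3ccc(Cl)c(C(F)(F)F)c3)cc2)c1`: 46500 nM

Compound 3 has the highest number of the three at 46500 nM, and so the weakest inhibition in this assay. Compound 4 `CNC(=O)CCc1ccc(NC(=O)Nc2ccc(Cl)c(C(F)(F)F)c2)cc1` replaces its aryl substituent, with 2-(methylcarbamoyl)ethyl in place of 3-(methylcarbamoyl)phenyl on an aromatic carbon, para to a large group: 2-(methylcarbamoyl)ethyl in place of 3-(methylcarbamoyl)phenyl on an aromatic carbon.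

Among the compounds with values here, two measured steps bear most directly on this change. Both introduce the 3-(methylcarbamoyl)phenyl group and both are modest: a 2.2-fold higher number from compound 2 to compound 3 (0.35 log units; beyond the scatter) and a 3.0-fold higher number from compound 1 to compound 3 (0.48 log units; beyond the scatter). The change on the amide nitrogen, a 1.4-fold higher number from compound 1 to compound 2 (0.13 log units; within the scatter), stays within the scatter. Within the data shown here, the group entering compound 4 has no ring, like the 2-(methylcarbamoyl)ethenyl group of compound 2, so a modest move back towards lower numbers is expected, although no saturated chain has yet been measured. The expected change is a 2.1-fold lower number from compound 3 to compound 4 (0.33 log units; beyond the scatter). For compound 4 the estimate is 22000 nM, with an expected range from 10000 nM to 50000 nM.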

Compound 4, half-maximal inhibitory concentration: 25200 nM
Compound 4: middle estimate off by 1.1-fold (0.06 log units), on the low side; the measured number falls inside the stated range.
By their numbers in this assay, from the lowest: compounds 1, 2, 4 and 3 (each within the scatter of the next, the first and the last beyond it).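

In this assay, swapping the aryl substituent for the ring-free chain gives a 1.8-fold lower number from compound 3 to compound 4 (0.27 log units; within the scatter), so this change, unlike the one that separated the ethenyl amide from the aryl amide in a 2.2-fold higher number from compound 2 to compound 3 (0.35 log units; beyond the scatter), does not clear the scatter. Reducing the linker from ethenyl to ethyl gives a 1.2-fold higher number from compound 2 to compound 4 (0.08 log units; within the scatter), and the comparison with the cyclobutyl amide gives a 1.6-fold higher number from compound 1 to compound 4 (0.21 log units; within the scatter), so the ethenyl linker is not required to stay level with either of those compounds at this position. Nothing measured here accounts for these differences.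

The compounds shown leave open whether a longer chain, or a carboxylic acid in place of the methyl amide at its end, would move the number beyond the scatter. They also leave open how a cyclobutyl amide would read on the ethyl chain.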